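The source may hold more compounds than are shown below. What is called first, only, known or untested is meant among the compounds shown, and "the series" means these compounds.

Compound 3 `COc1cc(-c2nn(-c3cccc(NC(=O)Nc4ccc(Cl)c(C(F)(F)F)c4)c3)cc2-c2ccncc2)ccc1Cl` gives 5010 nM in a functional assay on SK-MEL-28 cells (Homo sapiens) for inhibition, read by sulforhodamine B assay, with a stated time of 48 h (a lower number here means a stronger inhibitor of growth, a higher number a weaker inhibitor of growth), the higher of the two numbers measured; compound 2 `COc1cc(-c2nn(-c3cccc(NC(=O)Nc4cccc(C(F)(F)F)c4)c3)cc2-c2ccncc2)ccc1Cl` gives 3350 nM, and the step of a 1.5-fold higher number from compound 2 to compound 3 (0.17 log units; within the scatter) stays within the scatter. Compound 1 `COc1cc(-c2nn(-c3cccc(NC(=O)c4cccc(C(F)(F)F)c4)c3)cc2-c2ccncc2)ccc1Cl` reaches only a limit in this assay, > 50000 nM, as recorded in the limit of > 50000 nM in this assay, at which 1 of the 3 values shown sits. Compound 4 `COc1cc(-c2nn(-c3cccc(NC(=O)c4ccccc4)c3)cc2-c2ccncc2)ccc1Cl` differs from compound 3 by phenyl in place of (4-chloro-3-(trifluoromethyl)phenyl)amino on a carbonyl carbon, so the carbonyl carbon now carries the ring directly rather than through the amino group. The measured step that bears on this is an at least 9.9-fold lower number from compound 1 to compound 3 (0.99 log units; beyond the scatter), which ran in the opposite direction; an at least 14-fold lower number from compound 1 to compound 2 (1.17 log units; beyond the scatter) points the same way. Compound 4 is therefore expected to give a much higher number, probably again a limit, estimated at 50000 nM (from 15000 nM to 200000 nM), meaning a 10-fold higher number from compound 3 to compound 4 (1.00 log units; beyond the scatter).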

Compound 4, concentration for total growth inhibition: > 100000 nM
Compound 4: only a limit was reported (the forecaster's own chance of this, stated with the estimate: 70%); at least 2.0-fold (0.30 log units) between middle value and limit.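

On this carbonyl carbon, phenyl in place of either substituted phenylamino group weakens growth inhibition in this assay, with an at least 19-fold higher number from compound 3 to compound 4 (1.30 log units; beyond the scatter) and an at least 29-fold higher number from compound 2 to compound 4 (1.47 log units; beyond the scatter). Compound 4 reaches only a limit, so the ring without any substituent and without the amino group gives no measurable number: the limit of > 100000 nM in this assay, at which 1 of the 4 values shown sits. The step between compound 1 and compound 4 cannot be read, because both are limits, and any effect of the trifluoromethyl group on the amide stays unresolved: the limit of > 50000 nM in this assay, at which 1 of the 4 values shown sits.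

On these data alone, whether plain phenylamino, with neither chloro nor trifluoromethyl, keeps a measurable number remains open. So does the effect of a methylene chain or a sulfonamide at this position.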